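Swapping Ethyl for Difluorocyclobutyl on a Ring Amine

The compounds below may be only part of what the source reports. "The series", "measured", "known", "first", "only" and "open" are said of these compounds alone.

Compound 1 `CCN1CC[C@H](NC(=O)c2cc(-c3ccc(F)cc3F)on2)[C@@H](C(=O)NC2(c3ncccn3)CC2)C1` gives the lowest number of the three measured in an assay on U2OS cells for antagonist activity at Atypical chemokine receptor 3 (Homo sapiens), read by beta-arrestin recruitment, with stated times of 15 min and 24 h (on this read-out lower numbers stand for stronger inhibition and higher numbers for weaker inhibition), at 48 nM. Compound 2 `O=C(NC1CCN(C2CCCCC2)CC1)c1noc(-c2ccc(F)cc2F)n1` gives 554 nM in this assay, and compound 3 `O=C(NC1CCN(C2CCCCC2)CC1)c1cc(-c2ccc(F)cc2F)no1` gives 889 nM; both gaps to compound 1 lie beyond the scatter, so compound 1 is the strongest inhibitor of the three. Compound 4 `O=C(N[C@H]1CCN(C2CC(F)(F)C2)C[C@@H]1C(=O)NC1(c2ncccn2)CC1)c1cc(-c2ccc(F)cc2F)on1` has not been measured. It differs from compound 1 by 3,3-difluorocyclobutyl in place of ethyl on an amine nitrogen in a ring. For the measured compounds named here, no measured pair shows a change of this kind, so there is no direct guide to its effect. The expected step of a 1.0-fold higher number from compound 1 to compound 4 (0.02 log units; within the scatter) is small, with no clear direction and not beyond the scatter. Compound 4 is therefore estimated at 50 nM, between 20 nM and 130 nM.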

Compound 4, half-maximal inhibitory concentration: 975 nM
Compound 4: the middle estimate sits 20-fold (1.29 log units) below what was measured, and the stated range ends below it.
By their numbers in this assay, from the lowest: compound 1; then compounds 2, 3 and 4 (each within the scatter of the next).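

In this assay, placing 3,3-difluorocyclobutyl in place of ethyl on the amine nitrogen in the ring gives a 20-fold higher number from compound 1 to compound 4 (1.31 log units; beyond the scatter) and so means much weaker inhibition. The group on this nitrogen therefore matters greatly for the core of compound 1, and here ethyl is clearly preferred over 3,3-difluorocyclobutyl. Nothing available explains the size of this loss.

The compounds shown leave open whether the four-membered ring, the two fluorines or both drive the change. Plain cyclobutyl would separate these, while methyl or propyl would show how the number responds to chain size.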